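Pyrazoline amides: a larger substituent replaces the nitrooxy group

The source may report more compounds than this note shows. Statements on the series, on what has been measured and on what is new or still open speak of the compounds shown alone.

Measured compounds:
compound 1 `COc1ccc(C2=NN(C(=O)CBr)C(c3ccco3)C2)cc1OC`: 46%
compound 2 `COc1ccc(C2=NN(C(=O)CO[N+](=O)[O-])C(c3ccco3)C2)cc1OC`: 37%

In a functional assay on the whole organism (strain albino) for inhibition, with Rattus norvegicus as the target, read by paw edema, with stated times of 30 min and 2 h, at a dose of 100 mg/kg by the oral route (on this read-out lower numbers stand for less inhibition and higher numbers for more inhibition at the one dose given (going by the name of the read-out)), compound 2 gives 37%, the lowest of two numbers shown, while compound 1 gives 46%; the step of a number 9 percentage points lower from compound 1 to compound 2 (within the scatter) lies within the scatter. Compound 3 `COc1ccc(C2=NN(C(=O)CNc3ccc(/C(C)=N/O)cc3)C(c3ccco3)C2)cc1OC` is not yet measured. It differs from compound 2 by a group of 11 heavy atoms (8 carbon, 2 nitrogen, 1 oxygen; one six-membered aromatic ring of carbon only) in place of a group of 4 heavy atoms (1 nitrogen, 3 oxygen; no ring), on a saturated chain carbon bound to a carbonyl carbon. Going by the values given here, no measured step touches this change, and the one known step is small, so nothing beyond the scatter is expected. For compound 3 the estimate is 42%, with a range from 25% to 60%, an expected step of a number 5 percentage points higher from compound 2 to compound 3 (within the scatter).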

Compound 3, a percentage reported as inhibition, in the whole organism at one dose (the size of the read-out at that dose, not a potency): 46%
Compound 3: the middle estimate sits 4 percentage points below what was measured, and the stated range covers the measured number.
By their numbers in this assay, from the lowest: compounds 2, 1 and 3 (each within the scatter of the next).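

In this assay the larger group gives a number 9 percentage points higher from compound 2 to compound 3 (within the scatter), and set against the bromine atom it gives no change at the digits printed from compound 1 to compound 3 (within the scatter). On a saturated chain carbon bound to a carbonyl carbon, a group of 11 heavy atoms with a six-membered aromatic ring can thus take the place of nitrooxy or bromine with no change beyond the scatter, which the two ringless earlier compounds could not show. Nothing available explains this result. The compounds shown leave open how a plain amine or a carboxylic acid would read at this place.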